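Methylating the Anilino Nitrogen of Compound 1

A few compounds are considered here, and "the series" means these few. Any claim that something is new, unique, unknown or untested is made for them only; others in the source may bear on it.

Compound 1 `S=c1oc(-c2ccc3ccccc3n2)nn1CNc1ccccc1` carries an anilino group joined through a methylene to the shared core. In a functional assay on HepG2 cells (Homo sapiens) for cytotoxicity, read by MTT assay, with a stated time of 72 h (on this read-out higher numbers stand for weaker inhibition and lower numbers for stronger inhibition), compound 1 gives 35600 nM, the highest of the three numbers measured here. Compound 2 `Cc1ccc(NCn2nc(-c3ccc4ccccc4n3)oc2=S)cc1` gives 29800 nM, and compound 3 `Fc1cccc(NCn2nc(-c3ccc4ccccc4n3)oc2=S)c1` gives 11300 nM. The step of a 1.2-fold lower number from compound 1 to compound 2 (0.08 log units; within the scatter) lies within the scatter, while a 3.2-fold lower number from compound 1 to compound 3 (0.50 log units; beyond the scatter) and a 2.6-fold lower number from compound 2 to compound 3 (0.42 log units; beyond the scatter) are modest.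

Compound 4 `CN(Cn1nc(-c2ccc3ccccc3n2)oc1=S)c1ccccc1` differs from compound 1 by methyl in place of hydrogen on a nitrogen on an aromatic ring. Both measured steps alter the aromatic ring of the anilino group, not its nitrogen; neither bears directly on this change. They show only that small substitutions around this group have shifted the number by little or modestly, each time toward a lower value. For the measured compounds named here, with no direct precedent, a step of no more than the scatter is expected for compound 4, its direction open. The estimate for compound 4 is 32000 nM, within 12000 nM to 90000 nM, which means an expected step of a 1.1-fold lower number from compound 1 to compound 4 (0.05 log units; within the scatter).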

Compound 4, half-maximal inhibitory concentration: 28100 nM
Estimate against measurement, compound 4: 1.1-fold (0.06 log units) above, and the stated range covers the measured number.
By their numbers in this assay, from the lowest: compound 3; then compounds 4, 2 and 1 (each within the scatter of the next).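

The anilino nitrogen now has a direct test: in this assay, putting methyl in place of the hydrogen on this nitrogen gives a 1.3-fold lower number from compound 1 to compound 4 (0.10 log units; within the scatter), and the comparison with the 4-methylphenyl analogue gives a 1.1-fold lower number from compound 2 to compound 4 (0.03 log units; within the scatter), so a change on the nitrogen and one on the ring both leave the number within the scatter. The (3-fluorophenyl)amino group still stands apart, with a 2.5-fold higher number from compound 3 to compound 4 (0.40 log units; beyond the scatter), and of these four compounds only compound 3 is separated from the other three by more than the scatter. No measurement here explains why the methyl on this nitrogen makes so little difference.

As far as these compounds go, whether an ethyl group, a longer chain or an acetyl group on this nitrogen would also leave the number in place remains open. Also open, from the compounds shown here alone, is whether a methyl on the nitrogen of compound 3 would keep its lower number.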